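The source may hold more compounds than are shown below. What is called first, only, known or untested is meant among the compounds shown, and "the series" means these compounds.

Working notes on the dithiocarbamate series. Compound 1 `CC(C)NC(=O)N1CCN(C(=S)SCc2cn(Cc3ccccc3F)nn2)CC1` gives 7130 nM in a functional assay on SMMC-7721 cells (Homo sapiens) for cytotoxicity, read by MTT assay, with a stated time of 72 h; on this read-out higher numbers stand for weaker inhibition and lower numbers for stronger inhibition. Compound 2 `CC(C)(C)NC(=O)N1CCN(C(=S)SCc2cn(Cc3ccccc3F)nn2)CC1` reaches only the limit of this assay, > 128000 nM. The change between them, (methyl in place of hydrogen on a saturated chain carbon bound to an amide-type nitrogen and two saturated chain carbons), produced an at least 17-fold higher number from compound 1 to compound 2 (1.25 log units; beyond the scatter), consistent with the limit of > 128000 nM in this assay, at which 2 of the 3 values shown sit. Compound 3 `CCNC(=O)N1CCN(C(=S)SCc2cn(Cc3cc(OC)c(OC)c(OC)c3)nn2)CC1` also sits at the limit of this assay, > 128000 nM. The difference between the core of compound 1 and that of compound 3 is not broken down here. Compound 4 `COc1cc(Cn2cc(CSC(=S)N3CCN(C(=O)NC(C)C)CC3)nn2)cc(OC)c1OC` carries the change (methyl in place of hydrogen on a saturated chain carbon bound to an amide-type nitrogen and a saturated chain carbon); it is the same kind of change as in compound 2, though the place differs: there the carbon is bound to two saturated chain carbons, here to a saturated chain carbon. Since compound 3 gives only a limit, the step is expected to be an at least 2.5-fold lower number from compound 3 to compound 4 (0.40 log units; beyond the scatter) with wide uncertainty. Compound 4 is estimated at 50000 nM in this assay.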

Compound 4, half-maximal inhibitory concentration: > 128000 nM
Compound 4 was reported as a limit (the forecaster's own chance of this, stated with the estimate: 50%); at least 2.5-fold (0.40 log units) between middle value and limit.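

No new step can be read between compound 3 and compound 4, as both stand only as limits: the limit of > 128000 nM in this assay, at which 3 of the 4 values shown sit.

Going by these compounds, whether ethyl to isopropyl changes the read-out on the core of compound 3 remains open.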